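Amide nitrogen substituent survey: estimating compound 4

This account rests on a few compounds, and the source may have more. Where it says the series, first, only, none or still open, it means among the compounds named here.

Measured so far, with growth inhibition in a functional assay on SK-BR-3 cells (Homo sapiens) for inhibition, read by MTT assay; a lower number here means a stronger inhibitor of growth, a higher number a weaker inhibitor of growth:
compound 1 `CC1=C(/C=C/C(C)=C/C=C/C(C)=C\C(=O)NCc2ccc(F)cc2)C(C)(C)CCC1n1ccnc1` gives 5500 nM
compound 2 `CC1=C(/C=C/C(C)=C/C=C/C(C)=C\C(=O)Nc2ccc(F)cc2)C(C)(C)CCC1n1ccnc1` gives 25100 nM
compound 3 `CC1=C(/C=C/C(C)=C/C=C/C(C)=C\C(=O)NCc2ccc(O)cc2)C(C)(C)CCC1n1ccnc1` gives 2450 nM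

Compound 3 stands lowest of the three numbers in this assay, with compound 1 nearest and compound 2 furthest. Compound 4 `CC1=C(/C=C/C(C)=C/C=C/C(C)=C\C(=O)Nc2ccccc2)C(C)(C)CCC1n1ccnc1` differs from compound 3 by phenyl in place of 4-hydroxybenzyl on an amide-type nitrogen. Among the compounds with values here, two measured steps bear on it. Shortening benzyl to phenyl on the amide nitrogen gave a 4.6-fold higher number from compound 1 to compound 2 (0.66 log units; beyond the scatter); exchanging fluoro for hydroxy gave a 2.2-fold lower number from compound 1 to compound 3 (0.35 log units; beyond the scatter), so removing the hydroxy is read in the opposite direction. Both parts point toward a higher number, and together a step of the order of a 10-fold lower number from compound 2 to compound 3 (1.01 log units; beyond the scatter) reversed seems plausible. Compound 4 is therefore expected to show a 9.0-fold higher number from compound 3 to compound 4 (0.95 log units; beyond the scatter), landing near compound 2. The estimate for compound 4 is 22000 nM, within 8000 nM to 60000 nM.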

Compound 4, concentration for 50% growth inhibition: 1730 nM
Estimate against measurement, compound 4: 13-fold (1.10 log units) above; measured number outside the range, below it.
By their numbers in this assay, from the lowest: compounds 4 and 3 (each within the scatter of the next); then compound 1; then compound 2.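

In this assay, dropping the fluoro from the anilide of compound 2 has a large effect (a 15-fold lower number from compound 2 to compound 4 (1.16 log units; beyond the scatter)), so the weak result for compound 2 does not extend to phenyl itself on the amide nitrogen. Phenyl and 4-hydroxybenzyl cannot be told apart here (a 1.4-fold lower number from compound 3 to compound 4 (0.15 log units; within the scatter)), while phenyl still improves on 4-fluorobenzyl (a 3.2-fold lower number from compound 1 to compound 4 (0.50 log units; beyond the scatter)), so the loss from benzyl to phenyl rests on compound 2 alone. No measurement available here accounts for the fluoro effect.

Unsubstituted benzyl on the amide nitrogen remains open, as does the effect of an amine or a carboxylic acid on the phenyl ring of compound 4.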